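Amino for chloro on the fused core of the urea series

A few compounds are considered here, and "the series" means these few. Any claim that something is new, unique, unknown or untested is made for them only; others in the source may bear on it.

Compound 1 `Nc1nn(C(=O)Nc2ccc(Cc3ccccc3)cc2)c2ccccc12` gives 17000 nM in a functional assay on SNB-75 cells (Homo sapiens) for antiproliferative activity, read by sulforhodamine B assay, with a stated time of 48 h; a lower number here means a stronger inhibitor of growth, a higher number a weaker inhibitor of growth. Compound 2 `Nc1nn(C(=O)Nc2ccc(Cc3ccccc3)cc2)c2ccc(Cl)cc12` gives 14000 nM in this assay; the step of a 1.2-fold lower number from compound 1 to compound 2 (0.08 log units; within the scatter) is within the scatter, so compound 2 and compound 1 stand together on the two numbers shown. Compound 3 `Nc1ccc2c(c1)c(N)nn2C(=O)Nc1ccc(Cc2ccccc2)cc1` carries amino in place of chloro on an aromatic carbon. Among the measured compounds shown here, the only measured step at that carbon, a 1.2-fold lower number from compound 1 to compound 2 (0.08 log units; within the scatter), was within the scatter, so no step beyond the scatter is expected for a 1.1-fold higher number from compound 2 to compound 3 (0.06 log units; within the scatter). Compound 3 is estimated at 16000 nM in this assay, with a range from 6000 nM to 45000 nM.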

Compound 3, concentration for 50% growth inhibition: 17400 nM
The estimate for compound 3 lay 1.1-fold (0.04 log units) below the measured number; the measured number falls inside the stated range.
By their numbers in this assay, from the lowest: compounds 2, 1 and 3 (each within the scatter of the next).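

In this assay the amino group gives a 1.2-fold higher number from compound 2 to compound 3 (0.09 log units; within the scatter) and a 1.0-fold higher number from compound 1 to compound 3 (0.01 log units; within the scatter) so hydrogen, chloro and amino at this aromatic carbon now stand together. Amino brings a hydrogen-bond donor and a hydrogen-bond acceptor that chloro lacks, yet no step among these compounds lies beyond the scatter. No evidence at hand offers a reason for this.

On these data alone, whether a carboxylic acid or a longer chain at this carbon would give a step beyond the scatter remains open. As far as these compounds go, the effect of changes elsewhere on the shared core also remains open.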